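The source may report more compounds than this note shows. Statements on the series, on what has been measured and on what is new or still open speak of the compounds shown alone.

Among the measured compounds shown here, compound 2 `CN1CCCCC(n2nc(Cc3ccc(Cl)cc3)c3ccccc3c2=O)C1` gives 158 nM in an assay for binding affinity to Alpha-1A adrenergic receptor (Homo sapiens) (a higher number here means a weaker inhibitor, a lower number a stronger inhibitor), the lower of the two numbers measured so far, though compound 1 `CN1CCC[C@@H]1Cn1nc(Cc2ccc(F)c(F)c2)c2ccccc2c1=O`, with 200 nM in this assay, lies within the usual scatter of it, so the two cannot be told apart with confidence. Compound 3 `CN1CCC(Cn2nc(Cc3ccc(Cl)cc3)c3ccccc3c2=O)C1` keeps the shared core and the 4-chlorobenzyl group of compound 2 and changes only the amine-bearing substituent: (1-methylpyrrolidin-3-yl)methyl in place of 1-methylazepan-3-yl on an aromatic nitrogen. For the measured compounds named here, no pair of measured compounds differs in exactly this way, so there is no measured step to lean on. Both measured compounds carry a small ring with one nitrogen on this position and land close together, which gives no reason to expect a large shift in either direction beyond the scatter. The step from compound 2 to compound 3 in this assay is therefore expected to be small, a 1.3-fold higher number from compound 2 to compound 3 (0.10 log units; within the scatter). Compound 3 is estimated at 200 nM, within a range of 60 nM to 650 nM.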

Compound 3, inhibition constant: 100 nM
For compound 3 the middle estimate is 2.0-fold (0.30 log units) above the measured one; the measured number falls inside the stated range.
By their numbers in this assay, from the lowest: compounds 3, 2 and 1 (each within the scatter of the next).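

Among the compounds shown here, this is the first step at this position that can be read between two compounds differing in one place. In this assay, (1-methylpyrrolidin-3-yl)methyl in place of 1-methylazepan-3-yl gives a 1.6-fold lower number from compound 2 to compound 3 (0.20 log units; within the scatter) and so cannot be told apart from the ordinary variation between repeated measurements. With the shared core and the 4-chlorobenzyl group held fixed, the position therefore accepts either the seven-membered or the five-membered ring without a change beyond the scatter, and nothing available explains this result.

Both groups carry their nitrogen inside a ring with a methyl group on it. From the compounds shown here alone, the effect of an open-chain amine such as a dimethylaminoethyl chain, or of a ring without nitrogen such as cyclohexyl, remains open.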